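The source may report more compounds than this note shows. Statements on the series, on what has been measured and on what is new or still open speak of the compounds shown alone.

In a functional assay on HUVEC cells (Homo sapiens) for antiproliferative activity, read by MTT assay, with a stated time of 48 h (a lower number here means a stronger inhibitor, a higher number a weaker inhibitor), compound 1 (`Cc1ccccc1/C=C/c1nnc(-c2ccc3c(c2)OCCO3)o1`) stands level with compound 2 (`Cc1cccc(/C=C/c2nnc(-c3ccc4c(c3)OCCO4)o2)c1`): compound 1 gives 40500 nM and compound 2 gives 40600 nM in this read-out. Going by the values given here, the one measured step, 3-methylphenyl in place of 2-methylphenyl (a 1.0-fold higher number from compound 1 to compound 2 (0.00 log units; within the scatter)), lies within the scatter and keeps the methyl. Compound 3 (`O=[N+]([O-])c1ccccc1/C=C/c1nnc(-c2ccc3c(c2)OCCO3)o1`) carries a different change (nitro in place of methyl on an aromatic carbon): nitro in place of methyl on an aromatic carbon, ortho to a large group. Among the compounds with values here, no measured step covers that exchange, so no step beyond the scatter is expected in this assay in either direction. For compound 3 the estimate is 35000 nM with an expected range from 12000 nM to 100000 nM for the measurement. The estimated step (a 1.2-fold lower number from compound 1 to compound 3 (0.06 log units; within the scatter)) stays within the scatter.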

Compound 3, half-maximal inhibitory concentration: 25000 nM
For compound 3 the middle estimate is 1.4-fold (0.15 log units) above the measured one, and the stated range covers the measured number.
By their numbers in this assay, from the lowest: compounds 3, 1 and 2 (each within the scatter of the next).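

In this assay, nitro in place of methyl on an aromatic carbon, ortho to a large group, gives a 1.6-fold lower number from compound 1 to compound 3 (0.21 log units; within the scatter) and so stays within the scatter. The earlier pair moved only the methyl, whereas this result shows that a group of three heavy atoms with two hydrogen-bond acceptors can stand here without a step beyond the scatter. No measured evidence bears on why this is so. The compounds shown leave open whether an amine or a carboxylic acid at this position would give a step beyond the scatter.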